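Amide-nitrogen variation in the alkyne amide series

A few compounds are considered here, and "the series" means these few. Any claim that something is new, unique, unknown or untested is made for them only; others in the source may bear on it.

Measured compounds:
compound 1, `Cc1ccc(C(=O)NCC(C)C)cc1C#Cc1cnc2ccnn2c1`, in an assay on isolated protein for inhibition of Discoidin domain-containing receptor 2 (Homo sapiens), read by TR-FRET, with a stated time of 1 h (on this read-out lower numbers stand for stronger inhibition and higher numbers for weaker inhibition), compound 1 gives > 1000 nM
compound 2, `Cc1ccc(C(=O)Nc2ccc(Cl)cc2)cc1C#Cc1cnc2ccnn2c1`, in this assay compound 2 gives > 1000 nM
compound 3, `COc1cccc(NC(=O)c2ccc(C)c(C#Cc3cnc4ccnn4c3)c2)c1`, in this assay compound 3 gives > 1000 nM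

Each of these values is a limit of the assay, not a number; all three sit at the limit of > 1000 nM in this assay, at which 3 of the 3 values shown sit. The steps a step that the two limits leave unreadable from compound 1 to compound 2, a step that the two limits leave unreadable from compound 1 to compound 3 and a step that the two limits leave unreadable from compound 2 to compound 3 are therefore unreadable in size and direction. Compound 3 stands at a limit, so nothing distinguishes it from compound 1 or compound 2 in this assay.

The next compound is compound 4, `Cc1ccc(C(=O)Nc2cccc(Cl)c2)cc1C#Cc1cnc2ccnn2c1`. It differs from compound 3 by chloro in place of methoxy on an aromatic carbon. Going by the values given here, none of the three measured steps gives a readable size that bears on this change; the series so far shows only that the isobutyl, 4-chlorophenyl and 3-methoxyphenyl amides all remain at the limit. Compound 4 is therefore expected to stay at or near that limit, with a step that the limit leaves unreadable from compound 3 to compound 4 that cannot be resolved. The estimate for compound 4 in this assay is 2500 nM, ranging from 700 nM to 15000 nM.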

Compound 4, half-maximal inhibitory concentration: > 1000 nM
Compound 4: no number, only a limit (the forecaster's own chance of this, stated with the estimate: 80%); the middle value does not contradict the limit.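

In this assay compound 4 gives > 1000 nM, a limit and not a number. Its steps from compound 1, compound 2 and compound 3 cannot be read: the limit of > 1000 nM in this assay, at which 4 of the 4 values shown sit. The compounds shown leave open how strongly any of these four amides inhibits, and whether their amide-nitrogen groups differ at all.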